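A few compounds are considered here, and "the series" means these few. Any claim that something is new, unique, unknown or untested is made for them only; others in the source may bear on it.

Compound 1 `CCCCCCCCCCCCCCCCc1c(C)c(N(C)C)nc(C)c1O` and compound 2 `Cc1c(N(C)C)nc(CCCCCCCCCCO)c(O)c1C` share a core and differ in the chain hung on it. In a functional assay on cells (Lymphocyte), read by a luciferase reporter and ATP content, with a stated time of 48 h, tested at 5 uM (on this read-out lower numbers stand for a stronger effect and higher numbers for a weaker effect at the one concentration tested), compound 1 gives 96% and compound 2 gives 50%. Of these two numbers compound 2 stands lowest, the stronger effect, and the gap to compound 1 is beyond the usual scatter. Compound 3 `CCCCCCCCCCCCCCCCc1nc(N(C)C)c(C)c(C)c1O` has not yet been measured. It differs from compound 2 in one place: hexyl in place of hydroxy on a saturated chain carbon, ten or more bonds along the chain from an aromatic carbon. With this change the chain of compound 3 becomes as long as that of compound 1, which gives 96%, so the step is expected to go upward, toward a weaker effect, and beyond the scatter, about a number 35 percentage points higher from compound 2 to compound 3 (beyond the scatter) in this assay. Compound 3 is therefore expected to come out near 85%, somewhere between 60% and 100%.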

Compound 3, a percentage reported as activity, at one concentration (the size of the read-out at that concentration, not a potency): 100%
The estimate for compound 3 lay 15 percentage points below the measured number, and the stated range covers the measured number.
By their numbers in this assay, from the lowest: compound 2; then compounds 1 and 3 (each within the scatter of the next).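

In this assay, the end of the chain turns out to matter: hexyl in place of hydroxy on a saturated chain carbon, ten or more bonds along the chain from an aromatic carbon, gives a number 50 percentage points higher from compound 2 to compound 3 (beyond the scatter) and so a large move toward a weaker effect. A change this far along the chain is therefore not silent in this read-out. It also does two things at once, since it removes the hydroxy and lengthens the chain.

The step alone cannot separate these two, and that would take a plain decyl chain, a longer chain ending in hydroxy, or a chain ending in an amine or a carboxylic acid. Nothing measured here explains the rise in the number.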